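Swapping one ring on compound 2

The source may hold more compounds than are shown below. What is called first, only, known or untested is meant among the compounds shown, and "the series" means these compounds.

- compound 1 `CCOC(=O)c1ccc(N2C(=O)C(O)=C(C(=O)c3ccc(OC)cc3)C2c2ccc(F)cc2)cc1` gives 0.1 h
- compound 2 `COc1ccc(C(=O)C2=C(O)C(=O)N(c3ccc(-c4nc(C)no4)cc3)C2C2CCCCC2)cc1` gives 1 h

In an ADME assay on the whole organism for metabolic stability, with Rattus norvegicus as the target (a lower number here means that the compound disappears faster, a higher number that the compound lasts longer), compound 2 (1 h) holds the higher of the two numbers, and the gap down to compound 1 (0.1 h) lies beyond the usual scatter. Those two compounds differ in more than one place, so their gap says little about a single change. Compound 3 `COc1ccc(C(=O)C2=C(O)C(=O)N(c3ccc(-c4cc(C)no4)cc3)C2C2CCCCC2)cc1` differs from compound 2 in one place 3-methyl-1,2-oxazol-5-yl in place of 3-methyl-1,2,4-oxadiazol-5-yl on an aromatic carbon with 3-methyl-1,2-oxazol-5-yl in place of 3-methyl-1,2,4-oxadiazol-5-yl on an aromatic carbon. The estimated no change at the digits printed from compound 2 to compound 3 (within the scatter) is expected to stay within the scatter, in neither direction. The expected half-life of compound 3 is 1 h (range 0.3 h to 3 h).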

Compound 3, half-life: 1.1 h
For compound 3 the middle estimate is 1.1-fold (0.04 log units) below the measured one; low and high end bracket the measured number.
By their numbers in this assay, from the lowest: compound 1; then compounds 2 and 3 (each within the scatter of the next).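

For the compounds shown here, compound 2 and compound 3 give the first comparison here that turns on a single change. In this assay, putting 3-methyl-1,2-oxazol-5-yl in place of 3-methyl-1,2,4-oxadiazol-5-yl on this aromatic carbon gives a step that cannot be told from the scatter (a 1.1-fold higher number from compound 2 to compound 3 (0.04 log units; within the scatter)), so the two rings are interchangeable here for half-life. No supporting data speak to why the two rings read alike. As far as these compounds go, whether a group of another kind on that aromatic carbon, such as an amine or a carboxylic acid, would give a similar half-life stays open. Also open, from the compounds shown here alone, is whether this swap would read the same with a different group elsewhere on the shared core.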